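Aryl sulfonate series: pentyl to cyclopropyl on the urea

The source may report more compounds than this note shows. Statements on the series, on what has been measured and on what is new or still open speak of the compounds shown alone.

Measured so far in a functional assay on HT-1080 cells (Homo sapiens) for antiproliferative activity, read by sulforhodamine B assay, with a stated time of 48 h; on this read-out higher numbers stand for weaker inhibition and lower numbers for stronger inhibition:
compound 1, `CCCCCC(=O)Nc1ccc(S(=O)(=O)Oc2ccccc2I)cc1`: 9600 nM
compound 2, `O=C(CCCCl)Nc1ccc(S(=O)(=O)Oc2ccccc2I)cc1`: 12000 nM
compound 3, `CCCCCNC(=O)Nc1ccc(S(=O)(=O)Oc2ccccc2I)cc1`: 6900 nM

Compound 3 gives the lowest of the three numbers, but all gaps are small: a 1.4-fold lower number from compound 1 to compound 3 (0.14 log units; within the scatter) and a 1.7-fold lower number from compound 2 to compound 3 (0.24 log units; within the scatter) are within the scatter, as is a 1.3-fold higher number from compound 1 to compound 2 (0.10 log units; within the scatter). Compound 4, `O=C(Nc1ccc(S(=O)(=O)Oc2ccccc2I)cc1)NC1CC1`, carries cyclopropyl in place of pentyl on an amide-type nitrogen. Going by the values given here, no measured step changes the group on the amide-type nitrogen; the steps that alter the carbonyl substituent, a 1.4-fold lower number from compound 1 to compound 3 (0.14 log units; within the scatter) and a 1.7-fold lower number from compound 2 to compound 3 (0.24 log units; within the scatter), touch the same region and moved the numbers little. Nothing here therefore points to a step beyond the scatter in this assay in either direction. The expected step is a 1.2-fold higher number from compound 3 to compound 4 (0.06 log units; within the scatter), within the scatter. Compound 4 is expected at 8000 nM, estimated range 3000 nM to 20000 nM.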

Compound 4, half-maximal inhibitory concentration: 1300 nM
Estimate against measurement, compound 4: 6.2-fold (0.79 log units) above; measured number below the stated range.
By their numbers in this assay, from the lowest: compound 4; then compounds 3, 1 and 2 (each within the scatter of the next).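

In this assay, going by these compounds alone, the group on the amide-type nitrogen gives the first step beyond the scatter: cyclopropyl in place of pentyl yields a 5.3-fold lower number from compound 3 to compound 4 (0.72 log units; beyond the scatter) on this change alone. Cyclopropylamino on the carbonyl carbon also separates from the earlier carbonyl substituents, with a 7.4-fold lower number from compound 1 to compound 4 (0.87 log units; beyond the scatter) and a 9.2-fold lower number from compound 2 to compound 4 (0.97 log units; beyond the scatter) in the same direction. No available measurement bears on why this step occurs.

On these data alone, whether the step follows the three-membered ring or the smaller group remains open. A propyl, isopropyl or cyclobutyl group on the same nitrogen would separate these readings.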